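The compounds below may be only part of what the source reports. "The series", "measured", "known", "first", "only" and "open" are said of these compounds alone.

Measured so far in a functional assay on KB cells (Homo sapiens) for inhibition, read by sulforhodamine B assay; a lower number here means a stronger inhibitor of growth, a higher number a weaker inhibitor of growth:
compound 1 `c1ccc(-c2ccc(-c3ccc(-c4nc5ccccc5[nH]4)cc3)cc2)cc1`: 39700 nM
compound 2 `Cc1ccc2[nH]c(-c3ccc(-c4ccc(-c5cccc(Cl)c5)cc4)cc3)nc2c1`: 2260 nM
compound 3 `COc1cc(-c2ccc(-c3ccc(-c4nc5cc(C)ccc5[nH]4)cc3)cc2)cc(OC)c1OC`: 2110 nM

Compound 1 has the highest number of the three, which makes it the weakest growth inhibitor here. Compound 2 and compound 3 both lie well below it, beyond the scatter, and they sit within the scatter of each other.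

Compound 4 `Oc1ccc(-c2ccc(-c3ccc(-c4nc5ccccc5[nH]4)cc3)cc2)cc1` keeps the core of compound 1 and changes one place, from phenyl to 4-hydroxyphenyl: hydroxy in place of hydrogen on an aromatic carbon, para to a large group (hydroxy in place of hydrogen on an aromatic carbon). Among the compounds with values here, no measured pair shows this change alone, so any forecast is loose. Compound 2 at 2260 nM and compound 3 at 2110 nM show that much lower numbers than that of compound 1 occur in this small set, so a moderate fall in this assay is expected. The expected change is a 3.3-fold lower number from compound 1 to compound 4 (0.52 log units; beyond the scatter), towards stronger inhibition. For compound 4 the estimated value is 12000 nM, with an estimated range of 3000 nM to 40000 nM.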

Compound 4, concentration for 50% growth inhibition: 41000 nM
For compound 4 the middle estimate is 3.4-fold (0.53 log units) below the measured one; the whole stated range lies below it.
By their numbers in this assay, from the lowest: compounds 3 and 2 (each within the scatter of the next); then compounds 1 and 4 (each within the scatter of the next).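

In this assay, exchanging phenyl for 4-hydroxyphenyl gives a 1.0-fold higher number from compound 1 to compound 4 (0.01 log units; within the scatter), so the two compounds cannot be told apart. Within the data shown here, this is the first step here that isolates a single change, and it shows that this exchange, on an aromatic carbon para to a large group, leaves the growth-inhibition reading on the core of compound 1 effectively unchanged. Nothing available explains why this position gives no shift in the reading.

As far as these compounds go, whether a different group at this same place, such as an amine or a carboxylic acid, would change the number remains open. This single step also cannot tell whether hydroxy would behave the same way on a core that carries other changes.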